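The source may report more compounds than this note shows. Statements on the series, on what has been measured and on what is new or still open speak of the compounds shown alone.

Three compounds share one core and differ only in the aromatic group attached to the amide carbonyl carbon. Compound 1 `COc1ccccc1C(=O)Nc1cccc(-c2oc3cc(-c4ccc(F)cc4)ccc3c(=O)c2O)c1` carries a 2-methoxyphenyl there; in a functional assay on HCC1937 cells (Homo sapiens) for antiproliferative activity, read by CCK-8 assay, with a stated time of 72 h (on this read-out higher numbers stand for weaker inhibition and lower numbers for stronger inhibition), compound 1 gives 9050 nM. Compound 2 `CCc1ccc(C(=O)Nc2cccc(-c3oc4cc(-c5ccc(F)cc5)ccc4c(=O)c3O)c2)cc1` carries a 4-ethylphenyl, and in this assay compound 2 gives 13200 nM. Compound 3 `COc1cc(OC)cc(C(=O)Nc2cccc(-c3oc4cc(-c5ccc(F)cc5)ccc4c(=O)c3O)c2)c1` carries a 3,5-dimethoxyphenyl, and in this assay compound 3 gives 6250 nM. On these numbers compound 3 stands at the lower end: the step of a 2.1-fold lower number from compound 2 to compound 3 (0.32 log units; beyond the scatter) is a modest one beyond the scatter, whereas the step of a 1.4-fold lower number from compound 1 to compound 3 (0.16 log units; within the scatter) stays within the scatter, so compound 3 and compound 1 cannot be told apart.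

Compound 4 `O=C(Nc1cccc(-c2oc3cc(-c4ccc(F)cc4)ccc3c(=O)c2O)c1)c1cc(F)cc(F)c1` differs from compound 3 in one place: 3,5-difluorophenyl in place of 3,5-dimethoxyphenyl on a carbonyl carbon. Within the data shown here, the steps that bear on this are the earlier swaps of the same aromatic group, a 1.4-fold lower number from compound 1 to compound 3 (0.16 log units; within the scatter) and a 2.1-fold lower number from compound 2 to compound 3 (0.32 log units; beyond the scatter), both small, and all three groups tried so far land close together. Replacing the 3,5-dimethoxyphenyl with the 3,5-difluorophenyl is therefore expected to move the number little, if at all, beyond the scatter in this assay. The expected step in this assay is a 1.3-fold higher number from compound 3 to compound 4 (0.11 log units; within the scatter). Compound 4 is expected to give around 8000 nM, with a plausible range from 3500 nM to 18000 nM.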

Compound 4, half-maximal inhibitory concentration: 2070 nM
The estimate for compound 4 lay 3.9-fold (0.59 log units) above the measured number; measured number below the stated range.
By their numbers in this assay, from the lowest: compound 4; then compounds 3, 1 and 2 (each within the scatter of the next, the first and the last beyond it).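

Among these compounds, the first three aromatic groups on the amide carbonyl carbon gave values close together, so this position could have seemed to matter little, but in this assay the change of 3,5-dimethoxyphenyl to 3,5-difluorophenyl gives a 3.0-fold lower number from compound 3 to compound 4 (0.48 log units; beyond the scatter) even though the two groups carry their substituents at the same numbered ring positions. The other two comparisons, a 6.4-fold lower number from compound 2 to compound 4 (0.80 log units; beyond the scatter) and a 4.4-fold lower number from compound 1 to compound 4 (0.64 log units; beyond the scatter) as well, are also beyond the scatter, which places compound 4 clearly apart from the other three and shows that the group at this position can change the read-out, though the steps remain modest. Nothing measured here explains why the 3,5-difluorophenyl stands apart.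

The compounds shown leave open whether both fluorine atoms are needed, a question that a 3-fluorophenyl or a 4-fluorophenyl would address, and whether another halogen would act alike, as a 3,5-dichlorophenyl would show. A plain phenyl at the same place would also give a baseline against which all four substituted rings could be read.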